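Allyl to benzyl on the charged nitrogen: expected solubility

The compounds below may be only part of what the source reports. "The series", "measured", "known", "first", "only" and "open" are said of these compounds alone.

Compound 1, `COc1cc2cc(C(=O)CC3(O)CC[N+](C)(Cc4ccccc4)CC3)sc2cc1OC`, in a physicochemical assay for solubility (a lower number here means a less soluble compound, a higher number a more soluble compound), gives 1250 ug/mL.
Compound 2, `COc1cc2cc(CC3CC[N+](C)(Cc4ccccc4)CC3)sc2cc1OC`, gives 3000 ug/mL.
Compound 3, `C=CC[n+]1ccc(CCC(=O)c2cc3cc(OC)c(OC)cc3s2)cc1`, gives 25000 ug/mL.

Compound 3 stands highest of the three numbers; compound 2 lies nearest yet beyond the scatter below it, and compound 1 lies further below still. Compound 4, `COc1cc2cc(C(=O)CCc3cc[n+](Cc4ccccc4)cc3)sc2cc1OC`, differs from compound 3 by phenyl in place of vinyl on a saturated chain carbon bound to an aromatic nitrogen, the same difference read one bond further out as allyl to benzyl. Compound 4 has not yet been measured in this assay. A downward step beyond the scatter is expected, a 3.1-fold lower number from compound 3 to compound 4 (0.49 log units; beyond the scatter), partly because compound 2, which also carries a benzyl group on its charged nitrogen, gives 3000 ug/mL. Compound 4 is estimated at 8000 ug/mL, within a range from 3000 ug/mL to 20000 ug/mL.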

Compound 4, solubility: 2000 ug/mL
Beside the measured number, compound 4's estimate is 4.0-fold (0.60 log units) above it; measured number outside the range, below it.
By their numbers in this assay, from the lowest: compounds 1, 4 and 2 (each within the scatter of the next, the first and the last beyond it); then compound 3.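

The set now holds its first pair that differs in one place: in this assay, phenyl in place of vinyl on a saturated chain carbon bound to an aromatic nitrogen gives a 13-fold lower number from compound 3 to compound 4 (1.10 log units; beyond the scatter), a large step. This is one comparison at one place, so it shows the size of the change only on this core. Nothing measured here accounts for that size.

As far as these compounds go, whether a longer chain ending in phenyl, or an amine on the phenyl ring, would sit nearer compound 3 or compound 4 remains open. Also open, from the compounds shown here alone, is whether the same change would give a step of this size on the core of compound 2, which has no allyl partner here.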